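The source may hold more compounds than are shown below. What is called first, only, known or untested is meant among the compounds shown, and "the series" means these compounds.

The measured compounds:
Compound 1 `COc1nc(N)nc2c1c(-c1ccsc1)cn2[C@@H]1O[C@H](CO)[C@@H](O)[C@H]1O`: in a functional assay on HepG2 cells (Homo sapiens) for antiproliferative activity, read by XTT assay, with a stated time of 72 h (a higher number here means a weaker inhibitor, a lower number a stronger inhibitor), compound 1 gives only the limit > 20000 nM.
Compound 2 `C#Cc1cn([C@@H]2O[C@H](CO)[C@@H](O)[C@H]2O)c2nc(N)nc(OC)c12`: in this assay compound 2 gives only the limit > 20000 nM.
Compound 3 `C#Cc1cn([C@@H]2O[C@H](CO)[C@@H](O)[C@H]2O)c2ncnc(SC)c12`: in this assay compound 3 gives only the limit > 15000 nM.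

The step that the two limits leave unreadable from compound 2 to compound 1 cannot be read, because both values sit at the limit of > 20000 nM in this assay, at which 2 of the 3 values shown sit. The change made is thiophen-3-yl in place of ethynyl on an aromatic carbon. Compound 4 `CSc1ncnc2c1c(-c1ccsc1)cn2[C@@H]1O[C@H](CO)[C@@H](O)[C@H]1O` has not yet been measured; it differs from compound 3 by the same change, (thiophen-3-yl in place of ethynyl on an aromatic carbon), and the place is described in the same words. The difference between the core of compound 2 and the core of compound 3 is not broken down here. Compound 3 itself stands at the limit of > 15000 nM in this assay, at which 1 of the 3 values shown sits. With every measured value a limit, the earlier step offers no size to compare, and the new step is expected to be a step that the limit leaves unreadable from compound 3 to compound 4. Compound 4 is therefore estimated at 30000 nM, with a range from 10000 nM to 100000 nM.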

Compound 4, half-maximal inhibitory concentration: > 15000 nM
Compound 4 was reported as a limit; the forecaster's own chance of this, stated with the estimate: 85%; the middle value lies beyond the limit too.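

In this assay compound 3 and compound 4 both give only limits, so no size can be read for the step between them. The compounds shown leave open whether thiophen-3-yl in place of ethynyl changes activity at all.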